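The compounds below may be only part of what the source reports. "The series", "measured", "known", "first", "only" and "open" are said of these compounds alone.

Working notes on the series. Compound 3 `CCCCCCCC/C=C/CCCCCCC(C)(C)C(=O)Nc1c(OC)cc(OC)cc1OC` gives 44 nM in an assay on microsomes from intestine for inhibition of acyl-CoA:cholesterol acyltransferase (Oryctolagus cuniculus) (on this read-out lower numbers stand for stronger inhibition and higher numbers for weaker inhibition), and stands second highest of the three numbers recorded. Going by the values given here, compound 2 `CCCCCCCC/C=C/CCCCCCC(C)C(=O)Nc1c(OC)cc(OC)cc1OC` gives 36 nM in this assay; the only single-point step measured, a 1.2-fold higher number from compound 2 to compound 3 (0.09 log units; within the scatter), lies within the scatter. Compound 1 `CCCCCCCC/C=C/CCCCCCCC(=O)Nc1c(O)cc(OC)cc1OC` gives 150 nM in this assay, but it differs from compound 3 in more than one place, so its gap is not a single step.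

Compound 4 `CCCCCCCCC(C)(C)C(=O)Nc1c(OC)cc(OC)cc1OC` differs from compound 3 by a group of 2 heavy atoms (2 carbon; no ring) in place of a group of 10 heavy atoms (10 carbon; no ring), on a saturated chain carbon, seven bonds along the chain from a carbonyl carbon. Among the compounds with values here, no measured step bears on a change at this position; the measured step concerns only the methyl groups near the carbonyl. The expectation is therefore loosely held: compound 4 is estimated at 300 nM in this assay, between 60 nM and 2000 nM. This expected step, a 6.8-fold higher number from compound 3 to compound 4 (0.83 log units; beyond the scatter), is a guess beyond the scatter toward weaker inhibition.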

Compound 4, half-maximal inhibitory concentration: 59 nM
Compound 4: middle estimate off by 5.1-fold (0.71 log units), on the high side; measured number outside the range, below it.
By their numbers in this assay, from the lowest: compounds 2, 3 and 4 (each within the scatter of the next); then compound 1.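

At this position, seven bonds along the chain from a carbonyl carbon, ethyl in place of the group of 10 heavy atoms gives a 1.3-fold higher number from compound 3 to compound 4 (0.13 log units; within the scatter) in this assay. All earlier compounds carried the long unsaturated chain, and this pair shows that its removal leaves the number within the scatter. No measurement offered here accounts for this outcome.

Chain length and the double bond change together in this step, so their contributions cannot be separated. From the compounds shown here alone, a saturated chain matching that of compound 3, or an amine or carboxylic acid at this position, remains open.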